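Swapping pyridin-3-yl for a larger ring group

The compounds below may be only part of what the source reports. "The series", "measured", "known", "first", "only" and "open" are said of these compounds alone.

In a physicochemical assay for lipophilicity, measured as octanol-water partition, at pH 7.4 (on this read-out lower numbers stand for lower lipophilicity and higher numbers for higher lipophilicity), compound 3 `N#Cc1ccc(N[C@H]2CC[C@H](N(C(=O)NCc3ccccc3)c3ccc(-c4cccnc4)cc3)CC2)nc1` gives 3, within the scatter of both compound 1 `Cn1cc(-c2ccc(N(C(=O)NCc3ccccc3)[C@H]3CC[C@H](Nc4ccc(C#N)cn4)CC3)cc2)cn1` at 2.8 and compound 2 `N#Cc1ccc(N[C@H]2CC[C@H](N(C(=O)NCc3ccccc3)c3ccccc3)CC2)nc1` at 3.3. Compound 4 `Cn1cccc(-c2ccc(N(C(=O)NCc3ccccc3)[C@H]3CC[C@H](Nc4ccc(C#N)cn4)CC3)cc2)c1=O` changes one group of compound 3: a group of 8 heavy atoms (6 carbon, 1 nitrogen, 1 oxygen; one six-membered aromatic ring with 1 hetero atom) in place of a group of 6 heavy atoms (5 carbon, 1 nitrogen; one six-membered aromatic ring with 1 hetero atom), on an aromatic carbon. Three measured steps at this same place bear on the change, and they stayed limited: a number 0.20 log units higher from compound 1 to compound 3 (within the scatter), a number 0.30 log units lower from compound 2 to compound 3 (within the scatter) and a number 0.50 log units higher from compound 1 to compound 2 (beyond the scatter). Among the measured compounds shown here, no measured step involves the entering group, so the direction is a judgement rather than a read-across. The expected change is modest, a number 0.30 log units lower from compound 3 to compound 4 (within the scatter), and no larger than the widest step seen here. For compound 4 the estimated value is 2.7, with an expected range of 2.3 to 3.1.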

Compound 4, distribution coefficient: 2.7
The estimate for compound 4 equals the measured number at the digits printed; measured number inside the range.
By their numbers in this assay, from the lowest: compounds 4, 1, 3 and 2 (each within the scatter of the next, the first and the last beyond it).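

In this assay, the larger ring group cannot be told apart from the two smaller rings at this place: a number 0.30 log units lower from compound 3 to compound 4 (within the scatter) and a number 0.10 log units lower from compound 1 to compound 4 (within the scatter). Set against the bare hydrogen, however, it gives a step beyond the scatter, a number 0.60 log units lower from compound 2 to compound 4 (beyond the scatter), so a second ring group now separates from compound 2 in this way. Nothing available explains this shift. On these data alone, whether an amine or a carboxylic acid on this aromatic carbon would fall with these ring groups or with the hydrogen stays open.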